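The compounds below may be only part of what the source reports. "The series", "measured", "known", "first", "only" and "open" are said of these compounds alone.

Measured so far:
Compound 1 `CC(C)n1c(/C=C2/C(=O)Nc3ccccc32)nc2ccccc21` in a functional assay on MCF7 cells (Homo sapiens) for cytotoxicity, read by MTT assay, with a stated time of 48 h; a lower number here means a stronger inhibitor, a higher number a weaker inhibitor: compound 1 gives 39500 nM.
Compound 2 `CC(C)n1c(/C=C2/C(=O)Nc3ccc(Cl)cc32)nc2ccccc21` in this assay: compound 2 gives 24000 nM.

Within the data shown here, compound 2 holds the lowest of the two numbers, yet the only measured step, a 1.6-fold lower number from compound 1 to compound 2 (0.22 log units; within the scatter), is small, so compounds 1 and 2 cannot be told apart on these numbers.

Compound 3 `Cn1c(/C=C2/C(=O)Nc3ccc(Cl)cc32)nc2ccccc21` is the next compound. It keeps the chloro group of compound 2 and differs from it only in methyl in place of isopropyl on an aromatic nitrogen.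

Among the measured compounds shown here, no measured step bears on this change: the single step on hand, a 1.6-fold lower number from compound 1 to compound 2 (0.22 log units; within the scatter), concerns a chloro group on an aromatic carbon, not the group on the aromatic nitrogen, and that step itself stayed within the scatter. With nothing comparable to lean on, the expected step of no change at the digits printed from compound 2 to compound 3 (within the scatter) is none beyond the scatter, and the uncertainty is wide.

Compound 3 is therefore estimated at 24000 nM, with a range from 8000 nM to 72000 nM.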

Compound 3, half-maximal inhibitory concentration: > 50000 nM
Compound 3 gave a limit, no number; the forecaster's own chance of this, stated with the estimate: 10%; at least 2.0-fold (0.31 log units) between middle value and limit.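

Among these compounds, the group on the aromatic nitrogen matters in this assay: methyl in place of isopropyl gives an at least 2.0-fold higher number from compound 2 to compound 3 (0.31 log units; beyond the scatter), the first step in this short series that lies beyond the scatter. Among the compounds shown here, the earlier step, chloro in place of hydrogen on an aromatic carbon, could not separate compound 1 from compound 2, so this nitrogen is the first place where a single change can be read, and in this one pair the smaller group goes with the higher number. Compound 3 gives > 50000 nM, which is a limit and not a number, so the step fixes only a smallest size, and the series holds one reading of this kind: the limit of > 50000 nM in this assay, at which 1 of the 3 values shown sits.

The compounds shown leave open whether a longer chain such as butyl, or a benzyl group, on this nitrogen would give a lower number than isopropyl does in compound 2. They also leave open whether methyl in place of isopropyl would act in the same way on the core of compound 1, which carries no chloro group.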